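From tert-butyl to benzyl in a series held at a limit

The source may report more compounds than this note shows. Statements on the series, on what has been measured and on what is new or still open speak of the compounds shown alone.

Measured in an ADME assay on Huh-7 cells (Homo sapiens) for cytotoxicity, with a stated time of 72 h; a lower number here means that less compound is tolerated, a higher number that more compound is tolerated:
- compound 1 `Cc1cn([C@@H]2O[C@H](CO[Si](C)(C)C(C)(C)C)[C@@]3(OS(=O)(=O)C=C3N)[C@H]2O[Si](C)(C)C(C)(C)C)c(=O)n(C(=O)CCCC(N)=O)c1=O`: > 100000 nM, a limit
- compound 2 `Cc1cn([C@@H]2O[C@H](CO[Si](C)(C)C(C)(C)C)[C@@]3(OS(=O)(=O)C=C3N)[C@H]2O[Si](C)(C)C(C)(C)C)c(=O)n(C(=O)CCCC(=O)OC(C)(C)C)c1=O`: > 100000 nM, a limit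

Compound 2 has no number in this assay and sits at the limit of > 100000 nM in this assay, at which 2 of the 2 values shown sit.

Compound 3 `Cc1cn([C@@H]2O[C@H](CO[Si](C)(C)C(C)(C)C)[C@@]3(OS(=O)(=O)C=C3N)[C@H]2O[Si](C)(C)C(C)(C)C)c(=O)n(C(=O)CCCC(=O)OCc2ccccc2)c1=O` carries benzyl in place of tert-butyl on an oxygen next to a carbonyl group. The counted change is benzyl in place of tert-butyl on an oxygen next to a carbonyl group.

Within the data shown here, one measured step bears on this carbonyl, a step that the two limits leave unreadable from compound 1 to compound 2, and it offers no size to carry over. Both measured compounds sit at the limit, so no step beyond the scatter is expected, and no direction can be read from the data. The expected change is a number no higher from compound 2 to compound 3 (the limit leaves the size open). For compound 3 the estimate is 100000 nM, with an expected range of 50000 nM to 200000 nM, and another report as a limit is likely.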

Compound 3, half-maximal cytotoxic concentration: > 100000 nM
Compound 3: no number, only a limit; the forecaster's own chance of this, stated with the estimate: 85%; the middle value lies on the limit itself.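

No step can be read in this assay among compound 1, compound 2 and compound 3, because all three stand at one limit: the limit of > 100000 nM in this assay, at which 3 of the 3 values shown sit.

The compounds shown leave open whether amino, tert-butoxy or benzyloxy on the carbonyl carbon makes any difference to cytotoxicity, and at what concentration any of the three becomes cytotoxic.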